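The source may hold more compounds than are shown below. What is called first, only, known or untested is meant among the compounds shown, and "the series" means these compounds.

Working notes on the series.

Among the measured compounds shown here, compound 1 `O=C(CCN1C(=O)CSc2ccccc21)N1CCN(c2ccc(F)cc2)CC1` is the first measured member; in a functional assay on IMR-32 cells (Homo sapiens) for inhibition, read by sulforhodamine B assay, with a stated time of 48 h (on this read-out higher numbers stand for weaker inhibition of growth and lower numbers for stronger inhibition of growth), compound 1 gives 10000 nM. Compound 2 `O=C(CCN1C(=O)CSc2ccccc21)N1CCN(c2ccccc2)CC1` carries the same core with the fluoro removed. The value of compound 2 in this assay is a limit of the measurement, < 10 nM, not a number. The change hydrogen in place of fluoro on an aromatic carbon thus brings an at least 1000-fold lower number from compound 1 to compound 2 (3.00 log units; beyond the scatter); since one of the values is a limit (the limit of < 10 nM in this assay, at which 1 of the 3 values shown sits), the true size of this step is not known beyond the stated bound.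

Compound 3 `O=C(CCN1C(=O)CSc2ccccc21)NCCCN1CCN(c2ccccc2F)CC1` belongs to a second core; how this core differs from that of compound 1 is not broken down here. In this assay compound 3 gives 1400 nM.

Compound 4 `O=C(CCN1C(=O)CSc2ccccc21)NCCCN1CCN(c2ccccc2)CC1` is the not yet measured partner of compound 3, with the change (hydrogen in place of fluoro on an aromatic carbon). This is the same kind of change as from compound 1 to compound 2, but the place differs: there the fluoro sat para to a large group, here it sits ortho to a large group. For compound 4 a step of a 7.0-fold lower number from compound 3 to compound 4 (0.85 log units; beyond the scatter) is expected, resting on the large step of an at least 1000-fold lower number from compound 1 to compound 2 (3.00 log units; beyond the scatter), tempered because that step is bounded by the limit of < 10 nM in this assay, at which 1 of the 3 values shown sits, and because the place of the change is not the same. The estimate for compound 4 in this assay is 200 nM, between 20 nM and 1400 nM.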

Compound 4, concentration for 50% growth inhibition: > 100000 nM
Compound 4: no number, only a limit; the forecaster's own chance of this, stated with the estimate: 10%; at least 500-fold (2.69 log units) between middle value and limit.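

In this assay, hydrogen in place of fluoro on an aromatic carbon gives an at least 71-fold higher number from compound 3 to compound 4 (1.85 log units; beyond the scatter), which runs in the opposite direction to the step on the core of compound 1, so the change does not carry from one core to the other in this pair of cores: the same change on two cores in this assay, an at least 1000-fold lower number (3.00 log units; beyond the scatter) from compound 1 to compound 2 and an at least 71-fold higher number (1.85 log units; beyond the scatter) from compound 3 to compound 4, at least 71000-fold (4.85 log units) apart, beyond the scatter of two such steps

Compound 4 gives > 100000 nM, which is a limit and not a number, so the new step is known only as a bound: the limit of > 100000 nM in this assay, at which 1 of the 4 values shown sits.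

The two pairs do not show whether the core or the place of the fluoro, ortho to a large group in compound 3, lies behind the reversal, and two pairs support no rule for the series.

Open, as far as these compounds go, is how a 2-fluorophenyl on the core of compound 1 reads in this assay, a comparison that would separate the core from the place of the fluoro. Also open, from the compounds shown here alone, is how chloro or methoxy in that place, or a longer chain in the core of compound 3, behaves.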